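The source may report more compounds than this note shows. Statements on the series, on what has been measured and on what is new or still open speak of the compounds shown alone.

Among the measured compounds shown here, the compounds measured so far: compound 1 `CN(C(=O)NC(=O)c1ccc(Cl)cc1Cl)c1nc(C(F)(F)F)c(C(=O)N/N=C/c2ccc(C(F)(F)F)cc2)s1`, compound 2 `CN(C(=O)NC(=O)c1ccc(C(F)(F)F)cc1)c1nc(C(F)(F)F)c(C(=O)N/N=C/c2ccc(C(F)(F)F)cc2)s1` and compound 3 `CN(C(=O)NC(=O)c1ccccc1F)c1nc(C(F)(F)F)c(C(=O)N/N=C/c2ccccc2C(F)(F)F)s1`.

In a functional assay on HepG2 cells (Homo sapiens) for inhibition, read by MTT assay, with a stated time of 72 h (a lower number here means a stronger inhibitor, a higher number a weaker inhibitor), compound 1 gives 12.4 ug/mL. Compound 2 gives only a limit of this assay, > 100 ug/mL, which is the limit of > 100 ug/mL in this assay, at which 1 of the 3 values shown sits. Compound 3 gives 5.39 ug/mL, the lowest of the two numbers, and its nearest neighbour among them is compound 1. Compound 4 `CN(C(=O)NC(=O)c1ccccc1F)c1nc(C(F)(F)F)c(C(=O)N/N=C/c2ccc(C(F)(F)F)cc2)s1` differs from compound 3 by 4-(trifluoromethyl)phenyl in place of 2-(trifluoromethyl)phenyl on a carbon with a double bond to nitrogen. For the measured compounds named here, the only measured step, an at least 8.0-fold higher number from compound 1 to compound 2 (0.90 log units; beyond the scatter), sits on a carbonyl carbon rather than on the carbon doubly bonded to nitrogen, so it bears on this change only loosely. For compound 4 a small weakening is expected, a 1.5-fold higher number from compound 3 to compound 4 (0.17 log units; within the scatter), giving an estimate of 8 ug/mL with a range from 2.5 ug/mL to 30 ug/mL.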

Compound 4, half-maximal inhibitory concentration: 4.56 ug/mL
Estimate against measurement, compound 4: 1.8-fold (0.24 log units) above, within the range that was stated.
By their numbers in this assay, from the lowest: compounds 4 and 3 (each within the scatter of the next); then compound 1. At a limit, above all of these: compound 2.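

In this assay the step of a 1.2-fold lower number from compound 3 to compound 4 (0.07 log units; within the scatter) shows that this place carries either 2-(trifluoromethyl)phenyl or 4-(trifluoromethyl)phenyl with no difference beyond the scatter. With 4-(trifluoromethyl)phenyl held at that place, the group on the carbonyl carbon now separates the compounds: 2-fluorophenyl in place of 2,4-dichlorophenyl gives a 2.7-fold lower number from compound 1 to compound 4 (0.43 log units; beyond the scatter) and 2-fluorophenyl in place of 4-(trifluoromethyl)phenyl gives an at least 21-fold lower number from compound 2 to compound 4 (1.34 log units; beyond the scatter) on the same carbon. Compound 2 gives a limit, not a number: the limit of > 100 ug/mL in this assay, at which 1 of the 4 values shown sits.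

From the compounds shown here alone, whether an amine or a carboxylic acid on that phenyl ring, in place of trifluoromethyl, would give a similar number remains open.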